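Extending the imide methyl of compound 1 to a bromobutyl chain

The source may hold more compounds than are shown below. What is called first, only, known or untested is meant among the compounds shown, and "the series" means these compounds.

Measured compounds:
- compound 1, `Cc1ccc(S(=O)(=O)Nc2ccc3c(c2)C(=O)N(C)C3=O)cc1`: > 200000 nM
- compound 2, `O=C1c2ccccc2C(=O)N1CCNc1ccccc1`: > 200000 nM

Compound 1, `Cc1ccc(S(=O)(=O)Nc2ccc3c(c2)C(=O)N(C)C3=O)cc1`, was tested in an assay on isolated protein for inhibition of lactase/phlorizin hydrolase (Rattus norvegicus), read by colorimetric assay; a lower number here means a stronger inhibitor, a higher number a weaker inhibitor. In this assay compound 1 gives > 200000 nM, and this is a limit of the assay rather than a measured number. Compound 2, `O=C1c2ccccc2C(=O)N1CCNc1ccccc1`, is also known only through a limit in this assay, where compound 2 gives > 200000 nM. Compound 1 therefore stands nowhere in particular on the numbers shown: its own value is a limit, and the one further value shown is a limit as well, so that the limit of > 200000 nM in this assay, at which 2 of the 2 values shown sit, describes the whole of what has been measured.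

Compound 3, `Cc1ccc(S(=O)(=O)Nc2ccc3c(c2)C(=O)N(CCCCBr)C3=O)cc1`, has not yet been tested in this assay. It differs from compound 1 by 3-bromopropyl in place of hydrogen on a saturated chain carbon bound to an amide-type nitrogen in a ring. For the measured compounds named here, no step between measured compounds is available to say how such a change affects inhibition here. Since compound 1 is known only through a limit, the step from compound 1 to compound 3 cannot be resolved by the numbers, and no step beyond the scatter is expected in either direction, so the expected change is a step that the limit leaves unreadable from compound 1 to compound 3. Compound 3 is estimated at 300000 nM, with a range from 50000 nM to 2000000 nM, and it is expected that this assay will again most likely report only a limit for compound 3.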

Compound 3, half-maximal inhibitory concentration: > 200000 nM
Compound 3: a limit, no number (the forecaster's own chance of this, stated with the estimate: 85%); the middle value does not contradict the limit.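

For the compounds shown here, no step from compound 1 to compound 3 can be read in this assay, because each of the two is known only through a limit, as is compound 2: the limit of > 200000 nM in this assay, at which 3 of the 3 values shown sit.

The compounds shown leave open whether methyl to 4-bromobutyl on the core of compound 1 changes inhibition at all, and how weak any of these three compounds actually is.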